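The source may report more compounds than this note shows. Statements on the series, on what has been measured and on what is new or still open speak of the compounds shown alone.

Measured in an ADME assay on isolated protein for inhibition of sodium-dependent dopamine transporter (Homo sapiens); a lower number here means a stronger inhibitor, a higher number a weaker inhibitor:
compound 1 `O=C(NCCCCC(c1ccc(F)cc1)c1ccc(F)cc1)Nc1ccc(Cl)cc1` gives 15 nM
compound 2 `Cc1ccc(NC(=O)NCCCCC(c2ccc(F)cc2)c2ccc(F)cc2)cc1C` gives 80 nM
compound 3 `O=C(NCCCCN(c1ccc(F)cc1)c1ccc(F)cc1)Nc1ccc(Cl)cc1` gives 405 nM

Compound 3 carries the highest number of the three and is the weakest inhibitor in this assay, beyond the scatter from both compound 1 and compound 2. Compound 4 `O=C(NCCCCN(c1ccc(F)cc1)c1ccc(F)cc1)Nc1ccc(Cl)c(C(F)(F)F)c1` differs from compound 3 by trifluoromethyl in place of hydrogen on an aromatic carbon. Going by the values given here, no measured pair alters this exact position. Among the compounds with values here, the only step that touches the same aryl urea ring, a 5.3-fold higher number from compound 1 to compound 2 (0.73 log units; beyond the scatter), shows that changing the substitution of that ring moves this assay by a modest amount. A modest step is therefore expected for compound 4, with the direction uncertain. The estimate for compound 4 is 250 nM, with a range of 60 nM to 1200 nM. This corresponds to an expected step of a 1.6-fold lower number from compound 3 to compound 4 (0.21 log units; within the scatter).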

Compound 4, inhibition constant: 43 nM
For compound 4 the middle estimate is 5.8-fold (0.76 log units) above the measured one; the measured number lies below the stated range.
By their numbers in this assay, from the lowest: compound 1; then compounds 4 and 2 (each within the scatter of the next); then compound 3.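

In this assay, going by these compounds alone, trifluoromethyl ortho to the chloro group gives a 9.4-fold lower number from compound 3 to compound 4 (0.97 log units; beyond the scatter) and so fixes a direction at this position, which the earlier compounds left unread. Within the data shown here, the only earlier step on this ring, a 5.3-fold higher number from compound 1 to compound 2 (0.73 log units; beyond the scatter), swaps 4-chlorophenyl for 3,4-dimethylphenyl and does not isolate this position. No measurement at hand accounts for the step.

Going by these compounds, whether trifluoromethyl gives a similar step on the core of compound 1 remains open. Also open, on these data alone, is whether a nitrile or a methoxy group at this position matches it.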